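The compounds below may be only part of what the source reports. "The series", "measured", "known", "first", "only" and "open" are said of these compounds alone.

Measured so far:
Compound 1, `C=CC(=O)Nc1cccc(NC(=O)CSc2nc(Nc3ccccc3)c3ccccc3n2)c1`: in a functional assay on NCI-H1975 cells (Homo sapiens) for inhibition, read by MTT assay, with a stated time of 72 h (a higher number here means a weaker inhibitor, a lower number a stronger inhibitor), compound 1 gives 8120 nM.
Compound 2, `C=CC(=O)Nc1cccc(NC(=O)CSc2nc(Nc3ccccc3C)c3ccccc3n2)c1`: in this assay compound 2 gives 9920 nM.
Compound 3, `C=CC(=O)Nc1cccc(NC(=O)CSc2nc(Nc3cc(OC)c(OC)c(OC)c3)c3ccccc3n2)c1`: in this assay compound 3 gives > 50000 nM, which is a limit of the assay and not a number.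

Compound 3 therefore stands at the weak end of the numbers seen so far; of the three values it is the only one reported as a limit (the limit of > 50000 nM in this assay, at which 1 of the 3 values shown sits). Compound 4, `C=CC(=O)Nc1cccc(NC(=O)CSc2nc(Nc3ccc(Cl)cc3Cl)c3ccccc3n2)c1`, differs from compound 3 in one place: 2,4-dichlorophenyl in place of 3,4,5-trimethoxyphenyl on a nitrogen on an aromatic ring. For the measured compounds named here, no measured step involves a 2,4-dichlorophenyl group, so the closest guides are the two steps that lead into compound 3. an at least 6.1-fold higher number from compound 1 to compound 3 (0.78 log units; beyond the scatter) and an at least 5.0-fold higher number from compound 2 to compound 3 (0.70 log units; beyond the scatter); both put the 3,4,5-trimethoxyphenyl in place of a smaller aryl group, and both weaken inhibition beyond the scatter. Compound 4 again carries a smaller aryl group on that nitrogen, so the expected step of an at least 3.3-fold lower number from compound 3 to compound 4 (0.52 log units; beyond the scatter) is a move back toward a lower number, though its size is uncertain: compound 3 is known only as a limit. Compound 4 is therefore estimated at 15000 nM in this assay, with a plausible range from 5000 nM to 50000 nM.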

Compound 4, half-maximal inhibitory concentration: 5990 nM
The estimate for compound 4 lay 2.5-fold (0.40 log units) above the measured number, within the range that was stated.
By their numbers in this assay, from the lowest: compounds 4, 1 and 2 (each within the scatter of the next). At a limit, above all of these: compound 3.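

Replacing the 3,4,5-trimethoxyphenyl group with 2,4-dichlorophenyl gives an at least 8.3-fold lower number from compound 3 to compound 4 (0.92 log units; beyond the scatter), so the loss seen with compound 3 does not come with every substituted phenyl group on this nitrogen. Against the other two aryl groups, the new group gives a 1.7-fold lower number from compound 2 to compound 4 (0.22 log units; within the scatter) and a 1.4-fold lower number from compound 1 to compound 4 (0.13 log units; within the scatter); both steps lie within the scatter, so these three compounds cannot be put in order. In this assay, compound 3 remains the only one reported as a limit of the assay and not as a number: the limit of > 50000 nM in this assay, at which 1 of the 4 values shown sits.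

Which part of the 3,4,5-trimethoxyphenyl group goes with the loss stays open, including whether a single methoxy group on the phenyl ring would do the same. On these data alone, how a phenyl ring carrying an amine or a carboxylic acid would read in this assay is also open.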